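Fluoro for bromo on the aryl oxazole of compound 2

This account rests on a few compounds, and the source may have more. Where it says the series, first, only, none or still open, it means among the compounds named here.

Measured compounds:
compound 1, `O=[N+]([O-])c1ccc(CN2CCC(n3cc(CC(OCc4cc(-c5ccccc5)no4)c4ccc(Br)cc4)nn3)CC2)cc1`: > 25000 nM (a limit)
compound 2, `O=[N+]([O-])c1ccc(CN2CCC(n3cc(CC(OCc4cc(-c5ccc(Br)cc5)no4)c4ccc(Br)cc4)nn3)CC2)cc1`: 4000 nM

In a functional assay on MCF7 cells (Homo sapiens) for cytotoxicity, with a stated time of 48 h (on this read-out higher numbers stand for weaker inhibition and lower numbers for stronger inhibition), compound 2 gives 4000 nM. Within the data shown here, this is the only number among the two values shown. For compound 1 the assay records only a limit, > 25000 nM. Among the measured compounds shown here, the single measured step, an at least 6.2-fold lower number from compound 1 to compound 2 (0.79 log units; beyond the scatter), is therefore itself bounded by the limit, since it rests on (the limit of > 25000 nM in this assay, at which 1 of the 2 values shown sits). Compound 3, `O=[N+]([O-])c1ccc(CN2CCC(n3cc(CC(OCc4cc(-c5ccc(F)cc5)no4)c4ccc(Br)cc4)nn3)CC2)cc1`, differs from compound 2 by fluoro in place of bromo on an aromatic carbon. This change takes away the bromo that the step from compound 1 to compound 2 had introduced and puts fluoro in its place, so it partly reverses that step. On that basis compound 3 is expected to give a higher number than compound 2 in this assay, a step of a 3.0-fold higher number from compound 2 to compound 3 (0.48 log units; beyond the scatter), though not necessarily all the way back to where compound 1 stands. The estimate for compound 3 is 12000 nM, with a range from 4000 nM to 30000 nM.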

Compound 3, half-maximal inhibitory concentration: 7000 nM
Estimate against measurement, compound 3: 1.7-fold (0.23 log units) above, within the range that was stated.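

In this assay, among these compounds, the earlier compounds showed only that bromo on this aromatic carbon, para to a large group, goes with a measurable number; the new result shows that this does not depend on bromo alone. Fluoro in place of bromo gives a 1.8-fold higher number from compound 2 to compound 3 (0.24 log units; within the scatter), so the two halogens cannot be told apart at this position, while fluoro in place of hydrogen gives an at least 3.5-fold lower number from compound 1 to compound 3 (0.55 log units; beyond the scatter). Compound 3 thus joins compound 2 in standing apart from compound 1, which carries hydrogen here, but the true size of that separation stays unknown because compound 1 is recorded only as a limit: the limit of > 25000 nM in this assay, at which 1 of the 3 values shown sits.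

The compounds shown leave open whether a halogen is needed at all, since a methyl group, a methoxy group or an amine on this carbon would put that question directly. They also leave open whether chloro would fall in with fluoro and bromo, and whether a carboxylic acid here would keep a measurable number in this assay.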